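From an aromatic amine to a phenol on a shared core

This account rests on a few compounds, and the source may have more. Where it says the series, first, only, none or still open, it means among the compounds named here.

Compound 2 `COc1ccc(-c2cc3cc(C)ccc3c(-c3cccc(N)c3)n2)cc1OC` is one of two measured analogues built on the same core. In a functional assay on HCT-15 cells (Homo sapiens) for cytotoxicity, read by CCK-8 assay and cell counting, with a stated time of 72 h (on this read-out lower numbers stand for stronger inhibition and higher numbers for weaker inhibition), compound 2 gives 2700 nM, the higher of the two numbers recorded, though not by a margin that means anything. Going by the values given here, its only neighbour, compound 1 `COc1cccc(-c2nc(-c3ccc(OC)c(OC)c3)cc3cc(C)ccc23)c1`, gives 1840 nM in this assay. Among the compounds with values here, the single measured step, a 1.5-fold higher number from compound 1 to compound 2 (0.17 log units; within the scatter), exchanges a methoxy for an amino group on an aromatic carbon and leaves the two compounds within the scatter of each other.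

Compound 3 `COc1ccc(-c2cc3cc(C)ccc3c(-c3ccc(O)cc3)n2)cc1OC` has not been measured. It differs from compound 2 by 4-hydroxyphenyl in place of 3-aminophenyl on an aromatic carbon. Within the data shown here, the only measured step that bears on this change is a 1.5-fold higher number from compound 1 to compound 2 (0.17 log units; within the scatter), which also swapped one substituent on that phenyl group for another and did not move the number beyond the scatter. Among the measured compounds shown here, no measured pair speaks to the different substitution pattern of the incoming ring. The step from compound 2 to compound 3 is therefore expected to be small, a 1.2-fold lower number from compound 2 to compound 3 (0.09 log units; within the scatter), with no direction that can be trusted. Compound 3 is estimated at 2200 nM, within a range from 900 nM to 5500 nM.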

Compound 3, half-maximal inhibitory concentration: 2520 nM
Compound 3: middle estimate off by 1.1-fold (0.06 log units), on the low side; low and high end bracket the measured number.
By their numbers in this assay, from the lowest: compounds 1, 3 and 2 (each within the scatter of the next).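

In this assay, the step from 3-aminophenyl to 4-hydroxyphenyl on the aromatic carbon next to the ring nitrogen changes both the substituent and its place on the phenyl group, unlike the earlier step, yet it gives a 1.1-fold lower number from compound 2 to compound 3 (0.03 log units; within the scatter). Measured against the 3-methoxyphenyl group of compound 1, the same 4-hydroxyphenyl group gives a 1.4-fold higher number from compound 1 to compound 3 (0.14 log units; within the scatter), so 3-methoxyphenyl, 3-aminophenyl and 4-hydroxyphenyl all lie within the scatter of each other on this carbon, and the different substitution pattern has not separated the compounds. No evidence is available to explain why these three numbers stay together.

The three compounds do not separate the identity of the substituent from its place on the phenyl group, since that would need a pair such as 3-hydroxyphenyl and 4-hydroxyphenyl or 3-aminophenyl and 4-aminophenyl. Going by these compounds, it also remains open whether a plain phenyl group, a carboxylic acid on this phenyl group or a longer chain in its place would stay within the same narrow band or move the number beyond the scatter.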